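The source may report more compounds than this note shows. Statements on the series, on what has been measured and on what is new or still open speak of the compounds shown alone.

Measured so far in a functional assay on HCT-116 cells (Homo sapiens) for inhibition, read by MTT assay, with a stated time of 72 h; a lower number here means a stronger inhibitor, a higher number a weaker inhibitor: compound 1 `O=C1Nc2c(Br)cc(Br)cc2/C1=N/NC(=S)N1CCN(c2ccccc2)CC1` gives 6320 nM; compound 2 `Cc1ccccc1N1CCN(C(=S)N/N=C2\C(=O)Nc3ccc(Cl)cc32)CC1` gives 4910 nM; compound 3 `O=C1Nc2ccc(Cl)cc2/C1=N/NC(=S)N1CCN(c2ccc(Cl)cc2)CC1` gives 5390 nM.

The three numbers lie within the usual scatter of one another, so compound 3 is not set apart from compound 1 or compound 2 in this assay. For the measured compounds named here, the only measured change on the aryl group of the piperazine, a 1.1-fold higher number from compound 2 to compound 3 (0.04 log units; within the scatter), stayed within the scatter. Compound 4 `O=C1Nc2ccc(Cl)cc2/C1=N/NC(=S)N1CCN(c2ccc([N+](=O)[O-])cc2)CC1` carries nitro in place of chloro on an aromatic carbon, a change on that same aryl group. On this basis no movement beyond the scatter is expected, and the estimated step is a 1.0-fold lower number from compound 3 to compound 4 (0.02 log units; within the scatter). Compound 4 is therefore expected at about 5200 nM in this assay, with a range from 2600 nM to 10400 nM.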

Compound 4, half-maximal inhibitory concentration: 12000 nM
Compound 4: the middle estimate sits 2.3-fold (0.36 log units) below what was measured; the measured number lies above the stated range.
By their numbers in this assay, from the lowest: compounds 2, 3, 1 and 4 (each within the scatter of the next, the first and the last beyond it).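

In this assay, for the compounds shown here, the aryl group on the ring amine nitrogen is not indifferent to its substituent: nitro in place of chloro gives a 2.2-fold higher number from compound 3 to compound 4 (0.35 log units; beyond the scatter) and is the first change to pass the scatter. The step of a 2.4-fold higher number from compound 2 to compound 4 (0.39 log units; beyond the scatter) is also beyond the scatter and ends at the same 4-nitrophenyl group. No measurement shown explains the rise. An amine or a methoxy group on that aromatic carbon would test whether the rise is specific to nitro or extends to other groups at this place.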